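Compound 1 and Its 4-Chlorophenyl Counterpart, Compound 4

The compounds below may be only part of what the source reports. "The series", "measured", "known", "first", "only" and "open" are said of these compounds alone.

- compound 1 `Cc1ccc(C)c(NC(=O)Nc2nc(Sc3c[nH]c4ccccc34)cc(N3CCCCC3)n2)c1`: 6440 nM
- compound 2 `O=C(Nc1ccccc1)Nc1nc(Sc2c[nH]c3ccccc23)cc(N2CCN(Cc3ccccc3)CC2)n1`: 8160 nM
- compound 3 `O=C(Nc1ccccc1)Nc1nc(Nc2ccccc2)cc(Sc2c[nH]c3ccccc23)n1`: 14400 nM

These numbers come from a functional assay on HepG2 cells (Homo sapiens) for inhibition, with a stated time of 72 h; on this read-out lower numbers stand for stronger inhibition and higher numbers for weaker inhibition. Compound 1 cannot be told apart from compound 2, as their gap lies within the scatter. Compound 3 stands at a higher number than compound 1, and that gap lies beyond the scatter.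

Compound 4 `O=C(Nc1ccc(Cl)cc1)Nc1nc(Sc2c[nH]c3ccccc23)cc(N2CCCCC2)n1` is not yet measured. It carries 4-chlorophenyl in place of 2,5-dimethylphenyl on an amide-type nitrogen. For the measured compounds named here, no measured pair shows a change in one place, so the data give no direct guide to this swap. In this assay, no step beyond the scatter is expected, with an estimated 1.0-fold higher number from compound 1 to compound 4 (0.00 log units; within the scatter). For compound 4 the estimated value is 6500 nM, with an expected range from 2500 nM to 15000 nM.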

Compound 4, half-maximal inhibitory concentration: 14800 nM
Beside the measured number, compound 4's estimate is 2.3-fold (0.36 log units) below it; measured number inside the range.
By their numbers in this assay, from the lowest: compounds 1, 2, 3 and 4 (each within the scatter of the next, the first and the last beyond it).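

In this assay, for the compounds shown here, the swap of 2,5-dimethylphenyl for 4-chlorophenyl on the amide-type nitrogen reads as a 2.3-fold higher number from compound 1 to compound 4 (0.36 log units; beyond the scatter) and is the first change in a single place in this set. It shows that the number responds to the aromatic group at this position, though only modestly. Nothing measured here explains the step.

On these data alone, the two methyl groups leave and the chlorine enters together, and which of them matters stays open. Also open, as far as these compounds go, is how a methoxy group or a fluorine on this ring would read.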